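The compounds below may be only part of what the source reports. "The series", "measured", "known", "first", "only" and "open" are said of these compounds alone.

Notes on the series in a functional assay on A549 cells (Homo sapiens) for cytotoxicity, read by MTT assay, with a stated time of 72 h; a higher number here means a weaker inhibitor, a lower number a stronger inhibitor. Compound 1 (`COc1ccc(/C=C2\CCC/C(=C\c3cccc(Cl)c3)C2=O)cc1OC`) gives 11000 nM. Within the data shown here, compound 2 (`COc1ccc(/C=C2\CCC/C(=C\c3cccc(O)c3)C2=O)cc1OC`) gives 4300 nM, the lower of the two numbers so far. Compound 3 (`COc1ccc(/C=C2\CCC/C(=C\c3ccc(O)cc3)C2=O)cc1OC`) has 4-hydroxyphenyl in place of the 3-hydroxyphenyl of compound 2, on a double-bonded chain carbon bound to a double-bonded ring carbon: 4-hydroxyphenyl in place of 3-hydroxyphenyl on a double-bonded chain carbon bound to a double-bonded ring carbon. Among the measured compounds shown here, only one measured step bears on this, a 2.6-fold lower number from compound 1 to compound 2 (0.41 log units; beyond the scatter), a modest change with hydroxy in place of chloro on an aromatic carbon. For the measured compounds named here, that step shows a hydroxy compound with the lower number, but no measured pair tests moving the hydroxy, so the direction remains open. The expected step is a 1.1-fold lower number from compound 2 to compound 3 (0.03 log units; within the scatter), with nothing beyond the scatter anticipated. For compound 3 the estimate is 4000 nM, with an expected range of 1500 nM to 11000 nM.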

Compound 3, half-maximal inhibitory concentration: > 20000 nM
Compound 3: no number, only a limit; the forecaster's own chance of this, stated with the estimate: 3%; at least 5.0-fold (0.69 log units) between middle value and limit.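

In this assay, compound 3 gives a limit and not a number: the limit of > 20000 nM in this assay, at which 1 of the 3 values shown sits. Moving the hydroxy gives an at least 4.6-fold higher number from compound 2 to compound 3 (0.66 log units; beyond the scatter), so on a double-bonded chain carbon bound to a double-bonded ring carbon, 3-hydroxyphenyl and 4-hydroxyphenyl are not interchangeable, something the chloro-to-hydroxy swap could not show. The remaining step, an at least 1.8-fold higher number from compound 1 to compound 3 (0.25 log units; that floor lies within the scatter), shows that a hydroxy on the aromatic ring does not by itself go with the lower number: 3-hydroxyphenyl does so against 3-chlorophenyl, while 4-hydroxyphenyl does not.

Open, as far as these compounds go, is whether 4-chlorophenyl would part from 3-chlorophenyl as the hydroxy pair part, and whether 3-aminophenyl or 3-carboxyphenyl on the same carbon would follow 3-hydroxyphenyl. From the compounds shown here alone, the other aromatic group stays the same in all three compounds, so whether the hydroxy shift holds with a different group there also stays open.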